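A Chloro Group on the Phenyl of Compound 2

This account rests on a few compounds, and the source may have more. Where it says the series, first, only, none or still open, it means among the compounds named here.

In a functional assay on A549 cells (Homo sapiens) for cytotoxicity, read by MTT assay, with a stated time of 48 h (on this read-out lower numbers stand for stronger inhibition and higher numbers for weaker inhibition), compound 1 (`C=C(c1ccc(OC)cc1)c1cc(OC)c(OC)c(OC)c1-c1ccc(F)c(F)c1`) gives 6500 nM, and compound 2 (`C=C(c1ccc(OC)cc1)c1cc(OC)c(OC)c(OC)c1-c1ccccc1`) gives 22000 nM, the higher of the two numbers. Compound 3 (`C=C(c1ccc(OC)cc1)c1cc(OC)c(OC)c(OC)c1-c1ccc(Cl)cc1`) has chloro in place of hydrogen on an aromatic carbon, para to a large group: chloro in place of hydrogen on an aromatic carbon. Within the data shown here, one measured step bears on this, a modest one with phenyl replacing 3,4-difluorophenyl: a 3.4-fold higher number from compound 1 to compound 2 (0.53 log units; beyond the scatter). Chloro is a different halogen, so a similar or smaller step toward a lower number is expected: a 2.0-fold lower number from compound 2 to compound 3 (0.30 log units; within the scatter). The estimated value for compound 3 is 11000 nM, with a range from 4500 nM to 25000 nM.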

Compound 3, half-maximal inhibitory concentration: 29000 nM
Compound 3: the middle estimate sits 2.6-fold (0.42 log units) below what was measured, outside the stated range (above it).
By their numbers in this assay, from the lowest: compound 1; then compounds 2 and 3 (each within the scatter of the next).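

In this assay chloro in place of hydrogen on this phenyl, para to a large group, gives a step that stays within the scatter (a 1.3-fold higher number from compound 2 to compound 3 (0.12 log units; within the scatter)), so this change does not separate the two compounds. The 3,4-difluorophenyl of compound 1 stands apart from the 4-chlorophenyl as well (a 4.5-fold higher number from compound 1 to compound 3 (0.65 log units; beyond the scatter)), just as it does from the unsubstituted phenyl. Nothing available explains why chloro and the two fluoro groups differ here. On these data alone, whether a single fluoro, a methoxy or an amine on this phenyl, para to a large group, would come nearer to compound 1 stays open.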